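Methyl for Methoxy on the Aryl Ring of a Dicyanovinyl Indole

This account rests on a few compounds, and the source may have more. Where it says the series, first, only, none or still open, it means among the compounds named here.

Compound 1 `COc1ccc(-c2[nH]c3ccc(OC)cc3c2C=C(C#N)C#N)cc1`: 340 nM
Compound 2 `COc1ccc(-c2[nH]c3ccc(C)cc3c2C=C(C#N)C#N)cc1`: 200 nM
Compound 3 `CCCCc1ccc2[nH]c(-c3ccc(OC)cc3)c(C=C(C#N)C#N)c2c1`: 13 nM

Of the compounds shown here, three have been tested in a functional assay on MCF7 cells (Homo sapiens) for antiproliferative activity, with a stated time of 5 days; a lower number here means a stronger inhibitor, a higher number a weaker inhibitor. Compound 1 gives 340 nM in this assay, compound 2 gives 200 nM, and compound 3 gives 13 nM. Compound 2 differs from compound 1 by methyl in place of methoxy on an aromatic carbon, and this gives a 1.7-fold lower number from compound 1 to compound 2 (0.23 log units; within the scatter). Compound 3 differs from compound 1 by butyl in place of methoxy on an aromatic carbon, which gives a 26-fold lower number from compound 1 to compound 3 (1.42 log units; beyond the scatter). Between compound 2 and compound 3 the difference is a 15-fold lower number from compound 2 to compound 3 (1.19 log units; beyond the scatter).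

Compound 4 `CCCCc1ccc2[nH]c(-c3ccc(C)cc3)c(C=C(C#N)C#N)c2c1` has not yet been measured. It differs from compound 3 by methyl in place of methoxy on an aromatic carbon. Among the measured compounds shown here, this is the same kind of change as the one from compound 1 to compound 2, but not the same change: in compound 1 the ring carrying the group is part of a fused or bridged system of two rings, meta to a fused ring and para to a fused ring, whereas in compound 3 it is a six-membered aromatic ring of carbon only, para to a large group. How the two cores differ is given by butyl in place of methoxy on an aromatic carbon.

For compound 4 the expected step in this assay is a 1.4-fold lower number from compound 3 to compound 4 (0.16 log units; within the scatter), resting on the earlier step of a 1.7-fold lower number from compound 1 to compound 2 (0.23 log units; within the scatter), which lay within the scatter. The estimate for compound 4 is therefore 9 nM, expected to fall between 3 nM and 25 nM.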

Compound 4, half-maximal inhibitory concentration: 100 nM
Compound 4: middle estimate off by 11-fold (1.05 log units), on the low side, outside the stated range (above it).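

In this assay, the change from 4-methoxyphenyl to 4-methylphenyl gives a 7.7-fold higher number from compound 3 to compound 4 (0.89 log units; beyond the scatter). Set beside the earlier methyl-for-methoxy step, the result shows that this change did not carry over from one core to the other in this series: the same change on two cores in this assay, a 1.7-fold lower number (0.23 log units; within the scatter) from compound 1 to compound 2 and a 7.7-fold higher number (0.89 log units; beyond the scatter) from compound 3 to compound 4, 13-fold (1.12 log units) apart, beyond the scatter of two such steps. Among the compounds shown here, this shows that the outcome of the swap on one core gave no reliable guide to its outcome on the other, but it does not show why, since the swap sits on a different ring in each pair, the two cores also differ by butyl in place of methoxy, and each core offers only a single pair.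

The compounds shown leave open whether the gap follows from the ring that carries the group or from the butyl chain, a question that the 4-methoxyphenyl to 4-methylphenyl change on a core without butyl would address. They also leave open how other groups would behave at this place on the six-membered aromatic ring of carbon only, such as a hydroxyl, an amine or an ethoxy, and how a longer chain would compare with butyl.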